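Replacing the hexyl chain on the aromatic nitrogen with 4-nitrophenyl

The source may report more compounds than this note shows. Statements on the series, on what has been measured and on what is new or still open speak of the compounds shown alone.

Three compounds share one core and differ only in the group on a nitrogen on an aromatic ring. Compound 1 `CCCCCCNc1nc(SCc2ccc(C(F)(F)F)cc2)nc2ccccc12` carries hexyl there and gives 19000 nM in a functional assay on PC-3 cells (Homo sapiens) for cytotoxicity, read by MTT assay, with a stated time of 72 h (a lower number here means a stronger inhibitor, a higher number a weaker inhibitor), which places it second highest of the three numbers seen so far. Compound 2 `CCOc1ccccc1Nc1nc(SCc2ccc(C(F)(F)F)cc2)nc2ccccc12` carries 2-ethoxyphenyl and gives 26200 nM; the step of a 1.4-fold higher number from compound 1 to compound 2 (0.14 log units; within the scatter) is within the scatter. Compound 3 `FC(F)(F)c1ccc(CSc2nc(Nc3cccc(Br)c3)c3ccccc3n2)cc1` carries 3-bromophenyl and gives 8680 nM; the step of a 2.2-fold lower number from compound 1 to compound 3 (0.34 log units; beyond the scatter) is modest, as is the step of a 3.0-fold lower number from compound 2 to compound 3 (0.48 log units; beyond the scatter).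

Compound 4 `O=[N+]([O-])c1ccc(Nc2nc(SCc3ccc(C(F)(F)F)cc3)nc3ccccc23)cc1` is not yet measured. Its change from compound 1 is 4-nitrophenyl in place of hexyl on a nitrogen on an aromatic ring. Both earlier steps from compound 1 swap hexyl for an aromatic ring: compound 2 shows no step beyond the scatter, compound 3 a modest lowering. A step of similar or smaller size downward, or none beyond the scatter, is therefore expected for compound 4, which is estimated at 12000 nM with a range from 5000 nM to 30000 nM, an expected step of a 1.6-fold lower number from compound 1 to compound 4 (0.20 log units; within the scatter) from compound 1.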

Compound 4, half-maximal inhibitory concentration: 7900 nM
Compound 4: the middle estimate sits 1.5-fold (0.18 log units) above what was measured; low and high end bracket the measured number.
By their numbers in this assay, from the lowest: compounds 4 and 3 (each within the scatter of the next); then compounds 1 and 2 (each within the scatter of the next).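

In this assay, the step of a 2.4-fold lower number from compound 1 to compound 4 (0.38 log units; beyond the scatter) is modest, which makes 4-nitrophenyl the second aromatic group, after the 3-bromophenyl of compound 3, to go beyond the scatter from hexyl, while the 2-ethoxyphenyl of compound 2 goes against this. The step of a 1.1-fold lower number from compound 3 to compound 4 (0.04 log units; within the scatter) does not separate 4-nitrophenyl from 3-bromophenyl, whereas the step of a 3.3-fold lower number from compound 2 to compound 4 (0.52 log units; beyond the scatter) sets 4-nitrophenyl apart from 2-ethoxyphenyl, so the outcome at this nitrogen depends on which aromatic group enters and not on the presence of an aromatic ring alone. No measurement at hand accounts for these differences.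

On these data alone, it remains open whether a plain phenyl, or a phenyl ring carrying an amine or a carboxylic acid, would match 4-nitrophenyl and 3-bromophenyl. A chain shorter than hexyl at this nitrogen is also an open case.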